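From furan to thiophene on a shared core

The source may report more compounds than this note shows. Statements on the series, on what has been measured and on what is new or still open speak of the compounds shown alone.

In a functional assay on NCI-H460 cells (Homo sapiens) for antiproliferative activity, with a stated time of 72 h (a lower number here means a stronger inhibitor, a higher number a weaker inhibitor), compound 1 (`CCCC#Cc1cc([C@@H]2O[C@H](CO)[C@@H](O)[C@H]2O)n2ncnc(N)c12`) gives 400 nM, while compound 2 (`Nc1ncnn2c([C@@H]3O[C@H](CO)[C@@H](O)[C@H]3O)cc(-c3ccoc3)c12`) gives 1500 nM, the higher and therefore weaker of the two numbers. Compound 3 (`Nc1ncnn2c([C@@H]3O[C@H](CO)[C@@H](O)[C@H]3O)cc(-c3ccsc3)c12`) has thiophen-3-yl in place of furan-3-yl on an aromatic carbon. Going by the values given here, the only measured step, a 3.8-fold higher number from compound 1 to compound 2 (0.57 log units; beyond the scatter), is modest and put furan-3-yl in place of pent-1-yn-1-yl at that carbon. The new swap exchanges one five-membered aromatic ring for another, so no step beyond the scatter is expected, and the expected shift is small: a 1.3-fold lower number from compound 2 to compound 3 (0.10 log units; within the scatter). Compound 3 is estimated at 1200 nM, within a range of 400 nM to 3500 nM.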

Compound 3, half-maximal inhibitory concentration: 35600 nM
Beside the measured number, compound 3's estimate is 30-fold (1.47 log units) below it; measured number outside the range, above it.
By their numbers in this assay, from the lowest: compound 1; then compound 2; then compound 3.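

Two five-membered aromatic rings with matching counts of heavy atoms, donors and acceptors are not interchangeable at this carbon: in this assay, thiophen-3-yl in place of furan-3-yl gives a 24-fold higher number from compound 2 to compound 3 (1.38 log units; beyond the scatter). Against the pent-1-yn-1-yl group, the same ring gives an 89-fold higher number from compound 1 to compound 3 (1.95 log units; beyond the scatter), so this position can separate the three compounds widely. Nothing available explains why exchanging the ring oxygen for sulfur has so large an effect. Going by these compounds, it remains open whether an amine, a phenyl ring or a longer alkyne chain at this carbon would match compound 1 or fall towards compound 3.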